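This account rests on a few compounds, and the source may have more. Where it says the series, first, only, none or still open, it means among the compounds named here.

Compound 1, `COc1ccc2c(=O)c(/C=C/C(=O)Nc3ccccc3Cl)coc2c1`, gives 22400 nM in a functional assay on HeLa cells (Homo sapiens) for inhibition, read by MTT assay, with a stated time of 48 h; on this read-out higher numbers stand for weaker inhibition and lower numbers for stronger inhibition.
Compound 2, `COc1ccc2c(=O)c(/C=C/C(=O)NCc3ccc(F)cc3)coc2c1`, gives only an assay limit, > 100000 nM, in this assay.

For the measured compounds named here, of the two measured compounds, compound 2 is thus the one whose number is known only as a limit, the weaker-looking end of this small set. Compound 3, `COc1ccc2c(=O)c(/C=C/C(=O)NCc3ccc(F)cc3F)coc2c1`, differs from compound 2 by fluoro in place of hydrogen on an aromatic carbon. Going by the values given here, the one measured step, an at least 4.4-fold higher number from compound 1 to compound 2 (0.64 log units; beyond the scatter), swaps the whole group on the amide nitrogen and so bears only loosely on this much smaller change. What it does show is that compound 2 already sits at the limit of > 100000 nM in this assay, at which 1 of the 2 values shown sits. Among the compounds with values here, a single added fluoro is a small change, and no measured step of this exact kind exists here, so in this assay no step beyond the scatter is expected, that is a number no higher from compound 2 to compound 3 (the limit leaves the size open). Compound 3 is therefore estimated at 100000 nM, with a range from 30000 nM to 300000 nM, and most likely again only a limit.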

Compound 3, half-maximal inhibitory concentration: > 100000 nM
Compound 3 ended at the assay's limit (the forecaster's own chance of this, stated with the estimate: 70%); the middle value sits exactly at the limit.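

Compound 3, like compound 2, gives only a limit of the assay and not a number, so the step between them cannot be read, and the effect of the fluoro that enters, ortho to a large group and meta to a fluoro group, stays hidden. What can be read in this assay is that 2,4-difluorobenzyl in place of 2-chlorophenyl on the amide nitrogen gives an at least 4.4-fold higher number from compound 1 to compound 3 (0.64 log units; beyond the scatter), so a second group of the benzyl type also stays clearly short of the readable value. The limit now holds most of this small set: the limit of > 100000 nM in this assay, at which 2 of the 3 values shown sit.

The compounds shown leave open whether any benzyl group here can give a readable number, and whether the 2-chlorophenyl group of compound 1 would respond to an added fluoro. They also leave open what a longer chain ending in an amine would do on the amide nitrogen.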